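The compounds below may be only part of what the source reports. "The series", "measured", "known", "first", "only" and "open" are said of these compounds alone.

Measured so far:
- compound 1 `C=CC1=C(C(=O)O)C(c2ccc(OC)cc2)OC1`: 44300 nM
- compound 2 `C=CC1=C(C(=O)Nc2ccccc2)C(c2ccc(OC)cc2)OC1`: > 100000 nM
- compound 3 `C=CC1=C(C(=O)O)C(c2ccc(OC)c(OC)c2)OC1`: 18000 nM

In a functional assay on HeLa cells (Homo sapiens) for cytotoxicity, read by MTT assay, with a stated time of 24 h (a lower number here means a stronger inhibitor, a higher number a weaker inhibitor), compound 1 gives 44300 nM. Compound 3 gives 18000 nM in this assay, the lower of the two numbers, and the step of a 2.5-fold lower number from compound 1 to compound 3 (0.39 log units; beyond the scatter) comes from methoxy in place of hydrogen on an aromatic carbon. Compound 2, on the other hand, reaches only a limit of this assay, namely > 100000 nM, which is not a number. That limit, described by the limit of > 100000 nM in this assay, at which 1 of the 3 values shown sits, means the step of an at least 2.2-fold higher number from compound 1 to compound 2 (0.35 log units; beyond the scatter), made by anilino in place of hydroxy on a carbonyl carbon, is known only as a lower bound.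

Compound 4 `C=CC1=C(C(=O)Nc2ccccc2)C(c2ccc(OC)c(OC)c2)OC1` is not yet measured. It differs from compound 3 by anilino in place of hydroxy on a carbonyl carbon, the same change that turned compound 1 into compound 2; the two cores differ by methoxy in place of hydrogen on an aromatic carbon. Since that change gave an at least 2.2-fold higher number from compound 1 to compound 2 (0.35 log units; beyond the scatter), a weakening of similar or larger size is expected here, a 3.3-fold higher number from compound 3 to compound 4 (0.52 log units; beyond the scatter). Compound 4 is therefore estimated at 60000 nM in this assay, between 25000 nM and 150000 nM.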

Compound 4, half-maximal inhibitory concentration: 5030 nM
Estimate against measurement, compound 4: 12-fold (1.08 log units) above; the whole stated range lies above it.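

Anilino in place of hydroxy on a carbonyl carbon now gives a 3.6-fold lower number from compound 3 to compound 4 (0.55 log units; beyond the scatter), so in this assay this change does not carry from one core to the other with the same direction: the same change on two cores in this assay, an at least 2.2-fold higher number (0.35 log units; beyond the scatter) from compound 1 to compound 2 and a 3.6-fold lower number (0.55 log units; beyond the scatter) from compound 3 to compound 4, at least 8.0-fold (0.90 log units) apart, beyond the scatter of two such steps

Methoxy in place of hydrogen on an aromatic carbon lowers the number on both cores, but the size differs, with an at least 19-fold lower number from compound 2 to compound 4 (1.29 log units; beyond the scatter) set against the earlier step: the same change on two cores in this assay, a 2.5-fold lower number (0.39 log units; beyond the scatter) from compound 1 to compound 3 and an at least 19-fold lower number (1.29 log units; beyond the scatter) from compound 2 to compound 4, at least 8.0-fold (0.90 log units) apart, beyond the scatter of two such steps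

Compound 2 gives > 100000 nM, which is a limit and not a number, so the steps that involve it are known only as bounds, and these four compounds show that the two changes depend on each other here, but not why, nor whether this holds on any other core.

Still open, on these data alone, is whether a benzylamine or a simple methylamine amide would follow anilino on these two cores. As far as these compounds go, it is equally open whether an ethoxy group in place of methoxy would give a similar step.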